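The compounds below may be only part of what the source reports. "The series", "measured", "known", "first", "only" and "open" are said of these compounds alone.

Working notes on the series. Compound 1 `CC1CCN(C2CCN(S(=O)(=O)c3cccc(-c4ccccc4C(F)(F)F)c3)CC2)CC1` is one of three analogues on the shared core that have been run in an ADME assay on HCT-116 cells (Homo sapiens) for cytotoxicity, read by CellTiter-Glo, with a stated time of 72 h; a higher number here means a weaker inhibitor, a lower number a stronger inhibitor. In this assay compound 1 gives > 5000 nM, which is a limit of the assay and not a number. Compound 2 `CC1CCN(C2CCN(S(=O)(=O)c3sc(Cl)nc3C3CC3)CC2)CC1` gives > 10000 nM in this assay, likewise a limit. Compound 3 `CC1CCN(C2CCN(S(=O)(=O)c3ccc(OCc4ccccc4)cc3)CC2)CC1` gives > 5000 nM in this assay, again a limit. So compound 1 stands where the rest of the set stands: no measured value is a number, one sits at the limit of > 10000 nM in this assay, at which 1 of the 3 values shown sits, and two sit at the limit of > 5000 nM in this assay, at which 2 of the 3 values shown sit, compound 1 among the latter.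

Compound 4 `Cc1cc(C)cc(-c2cccc(S(=O)(=O)N3CCC(N4CCC(C)CC4)CC3)c2)c1` has not been measured. It differs from compound 1 in one place: 3,5-dimethylphenyl in place of 2-(trifluoromethyl)phenyl on an aromatic carbon.

Going by the values given here, no step between two measured compounds is available, so the size of this change cannot be read off a neighbouring pair. The step from compound 1 to compound 4 in this assay is expected to be none beyond the scatter, a step that the limit leaves unreadable from compound 1 to compound 4, because compound 1 gives only the limit > 5000 nM and nothing in the set points to a gain. For compound 4 the expected value in this assay is 9000 nM, with a range from 3000 nM to 30000 nM, most likely reported as a limit.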

Compound 4, half-maximal inhibitory concentration: > 5000 nM
Compound 4: only a limit was reported; the forecaster's own chance of this, stated with the estimate: 75%; the middle value is on the limit's open side.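

No new step can be read: compound 1 and compound 4 both give only limits in this assay, so the swap of 2-(trifluoromethyl)phenyl for 3,5-dimethylphenyl has no readable size. The compounds shown leave open where any of them would give an actual number, since every value is a limit: the limit of > 5000 nM in this assay, at which 3 of the 4 values shown sit.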